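Notes on the aryl change toward compound 3

The source may hold more compounds than are shown below. What is called first, only, known or untested is meant among the compounds shown, and "the series" means these compounds.

Compound 2 `CN(C)CCn1cnnc1-c1cc(Oc2ccc(NC(=O)N/N=C/c3cc(Br)c(O)c(Br)c3)cc2F)ccn1` holds the highest number of the two measured in a functional assay on NCI-H460 cells (Homo sapiens) for cytotoxicity, read by MTT assay, with a stated time of 72 h (on this read-out higher numbers stand for weaker inhibition and lower numbers for stronger inhibition), giving 3760 nM; its nearest neighbour, compound 1 `COc1ccc(/C=N/NC(=O)Nc2ccc(Oc3ccnc(-c4nncn4CCN(C)C)c3)c(F)c2)c(OC)c1`, gives 1570 nM. Among the measured compounds shown here, the only measured step, a 2.4-fold higher number from compound 1 to compound 2 (0.38 log units; beyond the scatter), is modest. Compound 3 `CN(C)CCn1cnnc1-c1cc(Oc2ccc(NC(=O)N/N=C/c3ccc(O)cc3)cc2F)ccn1` differs from compound 2 by 4-hydroxyphenyl in place of 3,5-dibromo-4-hydroxyphenyl on a carbon with a double bond to nitrogen. For the measured compounds named here, no measured pair shows this change directly; the step from compound 1 to compound 2 bears on it only loosely. The number for compound 3 is expected to sit near that of compound 2, with the estimated step of a 1.3-fold lower number from compound 2 to compound 3 (0.13 log units; within the scatter) staying within the scatter. Compound 3 is estimated at 2800 nM, with a range from 1100 nM to 7000 nM.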

Compound 3, half-maximal inhibitory concentration: 1780 nM
Compound 3: the middle estimate sits 1.6-fold (0.20 log units) above what was measured; measured number inside the range.
By their numbers in this assay, from the lowest: compounds 1 and 3 (each within the scatter of the next); then compound 2.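

On the carbon with a double bond to nitrogen, 4-hydroxyphenyl in place of 3,5-dibromo-4-hydroxyphenyl gives a 2.1-fold lower number from compound 2 to compound 3 (0.32 log units; beyond the scatter) in this assay, so the two bromine atoms alone separate this pair. The 4-hydroxyphenyl and 2,4-dimethoxyphenyl groups are not told apart at this place, with a 1.1-fold higher number from compound 1 to compound 3 (0.05 log units; within the scatter). No evidence here accounts for either step. Still open, as far as these compounds go, is whether a phenyl bearing one bromine reads like compound 2 or compound 3. Also open, from the compounds shown here alone, is how an amine or a carboxylic acid in place of the hydroxyl would read.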